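The compounds below may be only part of what the source reports. "The series", "measured", "known", "first", "only" and "open" are said of these compounds alone.

Measured in an ADME assay on NCM460 cells (Homo sapiens) for cytotoxicity, read by MTT assay, with a stated time of 24 h; on this read-out higher numbers stand for lower toxicity in this test and lower numbers for higher toxicity in this test

compound 1 `CC1(C)[C@H]2CC[C@]1(C)N(Cc1cn(-c3ccccc3C#N)nn1)C(=O)C2` gives 37500 nM
compound 2 `CC1(C)[C@H]2CC[C@]1(C)N(Cc1cn(-c3cccc(Cl)c3)nn1)C(=O)C2` gives 8410 nM

Within the data shown here, of the two numbers so far, the lower belongs to compound 2 (8410 nM). Next comes compound 3 `CC1(C)[C@H]2CC[C@]1(C)N(Cc1cn(-c3ccccc3)nn1)C(=O)C2`, which differs from compound 2 by hydrogen in place of chloro on an aromatic carbon, or 3-chlorophenyl to phenyl.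

Among the measured compounds shown here, only one measured step bears on this, and only indirectly: a 4.5-fold lower number from compound 1 to compound 2 (0.65 log units; beyond the scatter). For the measured compounds named here, that step replaces a 2-cyanophenyl, so it does not isolate the chloro, and the series holds no direct pair for that group. Still, the 3-chlorophenyl of compound 2 is tied to the lower number, so a modest upward step in this assay is expected, probably smaller than the measured one. That would most likely place compound 3 between the two measured compounds, though the range allows for no real change.

The expected change is a 2.3-fold higher number from compound 2 to compound 3 (0.35 log units; beyond the scatter). For compound 3 the estimated value is 19000 nM, with an expected range from 8000 nM to 45000 nM.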

Compound 3, half-maximal cytotoxic concentration: 19600 nM
The estimate for compound 3 lay 1.0-fold (0.01 log units) below the measured number, within the range that was stated.
By their numbers in this assay, from the lowest: compound 2; then compounds 3 and 1 (each within the scatter of the next).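

In this assay the chloro now has a direct pair: hydrogen in its place on the aromatic carbon meta to a large group gives a 2.3-fold higher number from compound 2 to compound 3 (0.37 log units; beyond the scatter) as a modest step beyond the scatter, so the lower number of compound 2 can be tied to this chloro itself and not merely to the absence of the 2-cyanophenyl. The cyano pair gives a 1.9-fold lower number from compound 1 to compound 3 (0.28 log units; within the scatter) and stays within the scatter, so the read-out does not separate the phenyl of compound 3 from the 2-cyanophenyl of compound 1, and among these three aryl groups only the 3-chlorophenyl of compound 2 stands apart from both others. Nothing on hand speaks to what lies behind the chloro step.

On these data alone, whether another group on that same aromatic carbon, such as a methoxy, an amine or a carboxylic acid, would go with a number like that of compound 2 or like that of compound 3 stays open. Also open, as far as these compounds go, is whether the chloro step carries over to a different ring position or to a core other than the one shared by these three compounds.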